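The compounds below may be only part of what the source reports. "The series", "measured", "known", "first", "only" and "open" are said of these compounds alone.

Working notes on the series. Compound 3 `O[C@@H]1Cc2cc(Cl)ccc2N[C@H](c2ccccc2Cl)C1` gives 106000 nM in an ADME assay on Vero cells (Chlorocebus sabaeus) for cytotoxicity, read by MTT assay, with a stated time of 72 h; on this read-out lower numbers stand for higher toxicity in this test and higher numbers for lower toxicity in this test. Of the two numbers reported so far, that of compound 3 is the lower, but the gap to compound 1 `O[C@@H]1Cc2cc(Cl)ccc2N[C@H](c2ccccc2)C1`, which gives 191000 nM in this assay, is within the scatter. Compound 2 `O[C@@H]1Cc2ccccc2N[C@H](c2ccccc2F)C1` is reported in this assay only as a limit, > 300000 nM.

Compound 4 `O[C@@H]1Cc2cc(Cl)ccc2N[C@H](c2ccccc2F)C1` differs from compound 3 by fluoro in place of chloro on an aromatic carbon. Among the compounds with values here, no measured step swaps chloro for fluoro on that ring. Within the data shown here, the only measured step, a 1.8-fold lower number from compound 1 to compound 3 (0.26 log units; within the scatter), concerns the chloro on the core and is within the scatter, so the chloro on the core does not move the number by itself. Compound 2 carries fluoro on the same aromatic carbon and no chloro on its core, and its value is a limit (the limit of > 300000 nM in this assay, at which 1 of the 3 values shown sits). From these data a step in this assay not beyond the scatter is expected, leaning if anything toward a higher number. Compound 4 is therefore expected to give about 160000 nM in this assay, with a range from 70000 nM to 300000 nM. The estimated step this implies is a 1.5-fold higher number from compound 3 to compound 4 (0.18 log units; within the scatter).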

Compound 4, half-maximal cytotoxic concentration: 182000 nM
Estimate against measurement, compound 4: 1.1-fold (0.06 log units) below; the range from low to high includes it.
By their numbers in this assay, from the lowest: compounds 3, 4 and 1 (each within the scatter of the next). At a limit, above all of these: compound 2.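

With the chloro on the core held, the aromatic carbon ortho to a large group now has three substituents compared: fluoro in place of chloro gives a 1.7-fold higher number from compound 3 to compound 4 (0.23 log units; within the scatter), and fluoro in place of hydrogen gives a 1.0-fold lower number from compound 1 to compound 4 (0.02 log units; within the scatter), so neither change moves the number in this assay beyond the scatter. Chloro in place of hydrogen on the core now has a second reading, an at least 1.6-fold lower number from compound 2 to compound 4 (0.21 log units; that floor lies within the scatter), and it can be set beside the first, though only as a floor: the same change on two cores in this assay, a 1.8-fold lower number (0.26 log units; within the scatter) from compound 1 to compound 3 and an at least 1.6-fold lower number (0.21 log units; that floor lies within the scatter) from compound 2 to compound 4; the limit leaves it open whether they differ. Within the data shown here, compound 2 is the one compound of the series that stands at a limit and not at a number: the limit of > 300000 nM in this assay, at which 1 of the 4 values shown sits.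

The compounds shown leave open whether a group of another kind on this aromatic carbon, such as an amine or a carboxylic acid, would give a step beyond the scatter in this assay. They also leave open the true size of the step for chloro in place of hydrogen on the core when fluoro is present, as only its floor can be read.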